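Methyl for Methoxy on the Benzoyl Ring of Compound 1

The source may hold more compounds than are shown below. What is called first, only, known or untested is meant among the compounds shown, and "the series" means these compounds.

Compound 1 `COC(=O)c1c(Nc2ccccc2)sc(C(=O)c2ccc(OC)cc2)c1C` is one of a small set of compounds sharing a common core and tested in a functional assay, with a stated time of 150 min, tested at 5 ug/mL; a higher number here means a stronger effect of the compound at the concentration tested, a lower number a weaker effect. In this assay compound 1 gives 13.3%, the higher of the two numbers reported; compound 2 `COC(=O)c1c(Nc2ccc(OC)cc2)sc(C(=O)c2ccc(OC)cc2)c1C` gives 4.29%, and compound 3 `COC(=O)c1c(Nc2ccc(Cl)cc2)sc(C(=O)c2ccc(OC)cc2)c1C` gives "not active" (no number reported), with no numerical value reported. Going by the values given here, the only single-step comparison available is a number 9 percentage points lower from compound 1 to compound 2 (within the scatter), a change on the aniline side of the core that stays within the scatter, so the two numbers cannot be ordered.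

Compound 4 `COC(=O)c1c(Nc2ccccc2)sc(C(=O)c2ccc(C)cc2)c1C` differs from compound 1 at the other end of the molecule: methyl in place of methoxy on an aromatic carbon. Among the compounds with values here, no measured pair describes a change at this position, so the expectation rests only on the size of the single step seen so far, which was within the scatter. On that basis compound 4 is expected to give a result close to compound 1, with a number 1.3 percentage points lower from compound 1 to compound 4 (within the scatter) expected to be no larger than the usual scatter. The estimate for compound 4 is therefore 12%, with a plausible range from 0% to 25%, and a real possibility that, like compound 3, only an inactive call and no number is reported.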

Compound 4, a percentage reported as activity, at one concentration (the size of the read-out at that concentration, not a potency): 2.08%
Estimate against measurement, compound 4: 9.9 percentage points above; measured number inside the range.
By their numbers in this assay, from the lowest: compounds 4, 2 and 1 (each within the scatter of the next, the first and the last beyond it).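

Swapping the 4-methoxyphenyl for the 4-methylphenyl gives a number a number 11.2 percentage points lower from compound 1 to compound 4 (beyond the scatter) in this assay, the first single change in this small set whose effect can be read beyond the usual scatter of the measurement. The group para to a large group therefore matters to the read-out, even though the size of the step is modest and the only change of this kind shown is at this one position. Methoxy has one hydrogen-bond acceptor and methyl has none, but that count only records how the two groups differ, and no measurement here shows why the number falls.

Still open, on these data alone, is how other groups at this place would read, for example a hydrogen, an amine, a carboxylic acid or a longer chain such as butoxy, and so whether the oxygen, the size of the group or something else goes with the higher number. Also open is whether the same swap would give a similar step with a substituted aniline at the other end of the molecule, and, as each number comes from one concentration, how potent any of these compounds is.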